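Cytotoxicity limits across three sulfone analogues and a pyridyl variant

The source may hold more compounds than are shown below. What is called first, only, known or untested is meant among the compounds shown, and "the series" means these compounds.

The set shares one core, shown by compound 1 `O=c1c(C2=CS(=O)(=O)c3cc(O)ccc3N2)c(O)c2cc(F)ccc2n1Cc1ccc(F)cc1`. In an ADME assay on 2209-23 cells (Homo sapiens) for cytotoxicity, read by WST assay (on this read-out lower numbers stand for higher toxicity in this test and higher numbers for lower toxicity in this test), compound 1 reaches only the assay limit, > 50000 nM. Compound 2 `CNC(=O)COc1ccc2c(c1)S(=O)(=O)C=C(c1c(O)c3cc(F)ccc3n(Cc3ccc(F)cc3)c1=O)N2` carries a (methylcarbamoyl)methyl group on the ring oxygen. In this assay compound 2 likewise sits at the limit, > 50000 nM. The step that the two limits leave unreadable from compound 1 to compound 2 is therefore unreadable. Compound 3 `CS(=O)(=O)Nc1ccc2c(c1)S(=O)(=O)C=C(c1c(O)c3cc(F)ccc3n(Cc3ccc(F)c(Cl)c3)c1=O)N2` bears a methanesulfonamide and a 3-chloro-4-fluorobenzyl group. In this assay compound 3 again gives only the limit, > 50000 nM. Compound 3 thus stands where every value of the set stands: the limit of > 50000 nM in this assay, at which 3 of the 3 values shown sit.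

Compound 4 `CS(=O)(=O)Nc1ccc2c(c1)S(=O)(=O)C=C(c1c(O)c3cc(F)ccc3n(Cc3cccnc3)c1=O)N2` differs from compound 3 by pyridin-3-yl in place of 3-chloro-4-fluorophenyl on a saturated chain carbon bound to an aromatic nitrogen. Going by the values given here, no measured step in this assay separates two real numbers: the one step that exists is the unreadable step from compound 1 to compound 2, and the remaining compounds stand only at the limit, so no size of effect is readable for any change at the saturated chain carbon bound to an aromatic nitrogen. The expectation for compound 4 in this assay is accordingly no step beyond the scatter, a number no higher from compound 3 to compound 4 (the limit leaves the size open), and most likely another limit. Compound 4 is estimated at 50000 nM in this assay, with a range from 20000 nM to 100000 nM.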

Compound 4, half-maximal cytotoxic concentration: > 50000 nM
Compound 4 ended at the assay's limit; the forecaster's own chance of this, stated with the estimate: 85%; the middle value lies on the limit itself.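

In this assay compound 4 gives > 50000 nM, a limit and not a number. No new step can be read between compound 3 and compound 4, which both stand only at a limit. Left open is how any change in the series, including pyridin-3-yl for 3-chloro-4-fluorophenyl, bears on the cytotoxic concentration: the limit of > 50000 nM in this assay, at which 4 of the 4 values shown sit.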